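Acylurea thiazole hydrazones: a nitrophenyl swap

The compounds below may be only part of what the source reports. "The series", "measured", "known", "first", "only" and "open" are said of these compounds alone.

The series shares the thiazole carbohydrazide scaffold of compound 3, `CN(C(=O)NC(=O)c1c(Cl)cccc1Cl)c1nc(C(F)(F)F)c(C(=O)N/N=C/c2ccccc2C(F)(F)F)s1`. In a functional assay on MCF7 cells (Homo sapiens) for inhibition, read by MTT assay, with a stated time of 72 h (on this read-out higher numbers stand for weaker inhibition and lower numbers for stronger inhibition), compound 3 gives 6.24 ug/mL. Compound 2, `CN(C(=O)NC(=O)c1ccc(C(F)(F)F)cc1)c1nc(C(F)(F)F)c(C(=O)N/N=C/c2cccc(C(F)(F)F)c2)s1`, gives 8.95 ug/mL in this assay; the two numbers lie within the scatter of each other, so neither can be called stronger. Among the compounds with values here, compound 1, `CNc1nc(C)c(C(=O)N/N=C/c2ccccc2C(F)(F)F)s1`, is the one member without the acylurea on the methylamino nitrogen; in this assay compound 1 gives only a limit, > 100 ug/mL. Within the data shown here, the pattern of the limit of > 100 ug/mL in this assay, at which 1 of the 3 values shown sits, sets compound 1 apart from compounds 2 and 3, but with no single-point step between measured compounds there is no measured size for any change.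

Compound 4, `CN(C(=O)NC(=O)c1cccc([N+](=O)[O-])c1)c1nc(C(F)(F)F)c(C(=O)N/N=C/c2ccccc2C(F)(F)F)s1`, differs from compound 3 by 3-nitrophenyl in place of 2,6-dichlorophenyl on a carbonyl carbon. Nothing measured here speaks to the direction of this exchange, so the expectation is a step from compound 3 to compound 4 of a 1.3-fold higher number from compound 3 to compound 4 (0.11 log units; within the scatter), no change beyond the scatter, in this assay. Compound 4 is therefore estimated at 8 ug/mL, in a range from 2.5 ug/mL to 30 ug/mL.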

Compound 4, half-maximal inhibitory concentration: 4.73 ug/mL
Beside the measured number, compound 4's estimate is 1.7-fold (0.23 log units) above it, and the stated range covers the measured number.
By their numbers in this assay, from the lowest: compounds 4, 3 and 2 (each within the scatter of the next). At a limit, above all of these: compound 1.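

The series now has its first measured step at a single place: in this assay, 3-nitrophenyl in place of 2,6-dichlorophenyl on a carbonyl carbon gives a 1.3-fold lower number from compound 3 to compound 4 (0.12 log units; within the scatter) and so no change beyond the scatter. At this position, with the rest of the structure held constant, this read-out does not separate the aryl carrying two chlorine atoms from the aryl carrying a nitro group, although the two groups differ in their atoms and in their counted hydrogen-bond acceptors. Nothing on hand bears on the reason for this step.

As far as these compounds go, whether any group at this position can move the number beyond the scatter remains open. An unsubstituted phenyl, a ring bearing a carboxylic acid or an amine, or a saturated alkyl chain in place of the aryl would test that.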